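Replacing trichloromethyl by nitro in a thiocarbamate series

This account rests on a few compounds, and the source may have more. Where it says the series, first, only, none or still open, it means among the compounds named here.

Measured compounds:
- compound 1 `CC(=O)Nc1ccc(OC(=S)Nc2ccc(Nc3ccc([N+](=O)[O-])cc3)cc2)cc1`: 4.32
- compound 2 `Oc1ccc(OC(=S)Nc2ccc(Nc3ccc(C(F)(F)F)cc3)cc2)cc1`: 6.04
- compound 3 `Oc1ccc(OC(=S)Nc2ccc(Nc3ccc(C(Cl)(Cl)Cl)cc3)cc2)cc1`: 6.79

In a physicochemical assay for lipophilicity (a lower number here means a more polar compound, a higher number a more lipophilic compound), compound 3 gives 6.79, the highest of the three numbers. The nearest is compound 2, and the step of a number 0.75 log units higher from compound 2 to compound 3 (beyond the scatter) lies beyond the scatter; compound 1, the furthest, stands well lower. Compound 4 `O=[N+]([O-])c1ccc(Nc2ccc(NC(=S)Oc3ccc(O)cc3)cc2)cc1` is not yet measured. It differs from compound 3 in one place: nitro in place of trichloromethyl on an aromatic carbon. Among the measured compounds shown here, no measured step shows this same exchange. For the measured compounds named here, the one measured step, a number 0.75 log units higher from compound 2 to compound 3 (beyond the scatter), concerns the trichloromethyl group that leaves, not the nitro group that enters. Going by the values given here, the only measured compound carrying a nitro group is compound 1, which gives 4.32 in this assay, although it also differs from compound 4 elsewhere. On this basis compound 4 is expected to fall well below compound 3, a step of a number 1.99 log units lower from compound 3 to compound 4 (beyond the scatter) beyond the scatter. The estimate for compound 4 in this assay is 4.8, with a range from 4.1 to 5.5.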

Compound 4, partition coefficient: 4.54
Beside the measured number, compound 4's estimate is 0.26 log units above it; the measured number falls inside the stated range.
By their numbers in this assay, from the lowest: compounds 1 and 4 (each within the scatter of the next); then compound 2; then compound 3.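

In this assay the exchange at this aromatic carbon, para to a large group, is large whichever halogenated group leaves: the step to nitro is a number 2.25 log units lower from compound 3 to compound 4 (beyond the scatter) for trichloromethyl and a number 1.50 log units lower from compound 2 to compound 4 (beyond the scatter) for trifluoromethyl, which places nitro well under both. Among the compounds shown here, with nitro held in place, hydroxy in place of acetamido on an aromatic carbon gives a number 0.22 log units higher from compound 1 to compound 4 (within the scatter) and leaves compound 1 and compound 4 indistinguishable, a pair the earlier compounds did not offer. Nothing at hand explains why these numbers differ. The compounds shown carry only nitro, trifluoromethyl and trichloromethyl at this carbon, so where a nitrile, a carboxylic acid or an amine would stand in this assay remains open. Also open, going by these compounds, is whether a step of this size would recur with acetamido in place of hydroxy, since compound 1 has no halogenated partner here.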